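Swapping fluoro for trifluoromethyl in compound 2

The source may hold more compounds than are shown below. What is called first, only, known or untested is meant among the compounds shown, and "the series" means these compounds.

Measured in a functional assay on A2780 cells (Homo sapiens) for inhibition, read by sulforhodamine B assay, with a stated time of 72 h; on this read-out lower numbers stand for stronger inhibition and higher numbers for weaker inhibition:
- compound 1 `O=C(NCc1ccc(S(=O)(=O)c2ccccc2)cc1)c1ccc2ncncc2c1`: > 10000 nM (a limit)
- compound 2 `O=C(NCc1ccc(S(=O)(=O)c2cccc(F)c2)cc1)c1cc2cnccc2[nH]1`: 11 nM
- compound 3 `O=C(Nc1ccc(S(=O)(=O)N2CCCCC2)cc1)c1cc2cnccc2[nH]1`: > 10000 nM (a limit)

Compound 2 gives the only true number among these three, 11 nM. The other two results are not numbers but limits: the limit of > 10000 nM in this assay, at which 2 of the 3 values shown sit.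

The next compound to be tested is compound 4 `O=C(NCc1ccc(S(=O)(=O)c2cccc(C(F)(F)F)c2)cc1)c1cc2cnccc2[nH]1`, which differs from compound 2 in one place: trifluoromethyl in place of fluoro on an aromatic carbon. Trifluoromethyl stands in place of fluoro on an aromatic carbon, so 3-fluorophenyl becomes 3-(trifluoromethyl)phenyl. No measured pair among these compounds shows a change of this kind, so the expectation rests on the structural change alone, and it is uncertain. A small weakening in this assay is expected, close to the usual scatter, with an estimated 1.8-fold higher number from compound 2 to compound 4 (0.26 log units; within the scatter). Compound 4 is estimated at 20 nM, with an expected range from 5 nM to 100 nM.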

Compound 4, half-maximal inhibitory concentration: 3 nM
Estimate against measurement, compound 4: 6.7-fold (0.82 log units) above, outside the stated range (below it).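

In this assay, placing trifluoromethyl on this aromatic carbon in place of fluoro gives a 3.7-fold lower number from compound 2 to compound 4 (0.56 log units; beyond the scatter), so this position accepts a group with more heavy atoms and inhibition grows stronger. The earlier compounds shown here could not show this, since compound 1 and compound 3 each differ from compound 2 in more than one place and no step could be read from them. Nothing measured here says why the swap strengthens inhibition.

Open, going by these compounds, is whether other groups at this position, such as chloro, methoxy, nitrile or an amine, would give a similar result in this assay. Also open, on these data alone, is whether the same swap would have a comparable effect at another carbon of this ring.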